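The source may report more compounds than this note shows. Statements on the series, on what has been measured and on what is new or still open speak of the compounds shown alone.

Series notes, cytotoxicity set.

Compound 1 `Cc1c(Br)cc2nc3n(c2c1Br)[C@H]1OC[C@@H](O)[C@H]1OC3` and compound 2 `Cc1c(Br)cc2c(nc3n2[C@H]2OC[C@@H](O)[C@H]2OC3)c1Br` share the same atoms joined differently; the difference between the two cores is not broken down here. In an ADME assay on HEp-2 cells (Homo sapiens) for cytotoxicity, read by MTT assay, with a stated time of 60 h (on this read-out lower numbers stand for higher toxicity in this test and higher numbers for lower toxicity in this test), compound 1 gives 250000 nM and compound 2 gives 34300 nM, so compound 2 sits at the lowest number of the three measured compounds. Compound 3 `Cc1ccc(S(=O)(=O)O[C@@H]2CO[C@H]3[C@@H]2OCc2nc4cc(Br)c(C)c(Br)c4n23)cc1` carries (4-methylphenyl)sulfonyl in place of hydrogen on an oxygen on a saturated carbon on the core of compound 1; in this assay compound 3 gives 88600 nM, which is a 2.8-fold lower number from compound 1 to compound 3 (0.45 log units; beyond the scatter).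

Compound 4 `Cc1ccc(S(=O)(=O)O[C@@H]2CO[C@H]3[C@@H]2OCc2nc4c(Br)c(C)c(Br)cc4n23)cc1` carries the same change on the core of compound 2, namely ((4-methylphenyl)sulfonyl in place of hydrogen on an oxygen on a saturated carbon); the change occurs twice among these compounds. The expectation for compound 4 in this assay is a step of about a 2.5-fold lower number from compound 2 to compound 4 (0.39 log units; beyond the scatter), about the size of the measured step from compound 1 to compound 3, and resting on that single step because compound 3 gives 88600 nM. From the compounds shown here alone, whether the step carries over to the other core is untested. Compound 4 is estimated at 14000 nM, expected to fall between 5000 nM and 40000 nM.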

Compound 4, half-maximal cytotoxic concentration: 8940 nM
Compound 4: the middle estimate sits 1.6-fold (0.19 log units) above what was measured; low and high end bracket the measured number.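

In this assay, (4-methylphenyl)sulfonyl in place of hydrogen on an oxygen on a saturated carbon gives a 3.8-fold lower number from compound 2 to compound 4 (0.58 log units; beyond the scatter), and this step agrees with the earlier one on the other core: the same change on two cores in this assay, a 2.8-fold lower number (0.45 log units; beyond the scatter) from compound 1 to compound 3 and a 3.8-fold lower number (0.58 log units; beyond the scatter) from compound 2 to compound 4, 1.4-fold (0.13 log units) apart, within the scatter of two such steps On these two cores the change therefore carries over in direction and, within the scatter, in size, with the lower number standing for higher toxicity in this test. This rests on one pair per core, one substituent and one cell test, so it does not show that the step would hold on any further core, and it gives no reason for the step.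

Still open, from the compounds shown here alone, is whether the whole (4-methylphenyl)sulfonyl group is needed for the step, or whether a smaller methanesulfonyl group or a plain acetyl ester on the same oxygen would move the number the same way. Also open, going by these compounds, is how an amine in place of that oxygen, or a longer alkyl chain on it, would read in this assay.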